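The source may hold more compounds than are shown below. What is called first, only, known or untested is meant among the compounds shown, and "the series" means these compounds.

Measured compounds:
compound 1 `COc1ccc(/C=C/C[C@@H]2C[C@@H]([C@@H](OC(C)=O)c3ccc(OC)c(OC)c3)CO[C@H]2c2ccc(OC)c(OC)c2)cc1OC`: 48%
compound 2 `COc1ccc(/C=C/C[C@@H]2C[C@@H]([C@@H](OC)c3ccc(OC)c(OC)c3)CO[C@H]2c2ccc(OC)c(OC)c2)cc1OC`: 34%

In a functional assay on HeLa cells (Homo sapiens) for cytotoxicity, read by WST assay, with a stated time of 48 h, tested at 100 uM (on this read-out higher numbers stand for more inhibition at the one concentration tested (going by the name of the read-out) and lower numbers for less inhibition), compound 1 gives 48%, the higher of the two numbers shown, while compound 2 gives 34%. Among the compounds with values here, the one measured step is a number 14 percentage points lower from compound 1 to compound 2 (beyond the scatter), which comes with methyl in place of acetyl on an oxygen on a saturated carbon.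

Compound 3 `COc1ccc(/C=C/C[C@H]2C[C@@H]([C@@H](OC(C)=O)c3ccc(OC)c(OC)c3)CO[C@@H]2c2ccc(OC)c(OC)c2)cc1OC` keeps the acetyl of compound 1, and the change is one of configuration only: the two compounds have the same atoms and bonds and differ only in configuration as drawn: 2 of 5 stereo elements differ; a stereocentre at a saturated ring carbon is drawn R in compound 1 and S in compound 3; a stereocentre at a saturated ring carbon is drawn R in compound 1 and S in compound 3. No measured step concerns a change of configuration, and the single step shown, a number 14 percentage points lower from compound 1 to compound 2 (beyond the scatter), concerns a different part of the molecule and so offers no guidance on this pair. The expectation therefore rests on compound 1 alone, with a wide range. The expected step in this assay is a number 8 percentage points lower from compound 1 to compound 3 (within the scatter), a change not clearly beyond the scatter in either direction. Compound 3 is estimated at 40%, with a range from 15% to 65%.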

Compound 3, a percentage reported as inhibition, at one concentration (the size of the read-out at that concentration, not a potency): 29%
Compound 3: the middle estimate sits 11 percentage points above what was measured; measured number inside the range.
By their numbers in this assay, from the lowest: compounds 3 and 2 (each within the scatter of the next); then compound 1.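

In this assay, within the data shown here, the one earlier step concerned only the group on the oxygen, whereas here the acetyl stays in place and the read-out still moves: a number 19 percentage points lower from compound 1 to compound 3 (beyond the scatter). This shows that the result at this concentration depends on how the two saturated ring carbons are drawn, and not only on what is attached to that oxygen. The step can be assigned to configuration alone, because no atom or bond changes: the fact that compounds 1 and 3 differ only in the configuration as drawn

The compounds shown leave open whether one of the two stereocentres alone carries the step, since in compound 3 the two change together. They also leave open how a free hydroxyl or an amine on that saturated carbon would read in either configuration.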